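The source may hold more compounds than are shown below. What is called first, only, known or untested is meant among the compounds shown, and "the series" means these compounds.

Among the compounds with values here, compound 2 `COc1ccccc1N1CCN(CC2Nc3cc(C)ccc3S(=O)(=O)N2)CC1` gives 5.98 in a functional assay on thoracic aorta for antagonist activity at Alpha-1D adrenergic receptor (Rattus norvegicus) (on this read-out lower numbers stand for lower potency and higher numbers for higher potency (the scale is a negative logarithm)), the higher of the two numbers so far; compound 1 `COc1ccccc1N1CCN(CC2Nc3ccccc3S(=O)(=O)N2)CC1` gives 5.34 in this assay. Within the data shown here, the single measured step, a number 0.64 log units higher from compound 1 to compound 2 (beyond the scatter), is the only guide. Compound 3 `COc1ccccc1N1CCN(CC2Nc3cc(Cl)ccc3S(=O)(=O)N2)CC1` differs from compound 2 by chloro in place of methyl on an aromatic carbon. Among the measured compounds shown here, no measured pair swaps methyl for chloro, so the expectation rests on the fact that substitution at this carbon already moved compound 2 upward by a number 0.64 log units higher from compound 1 to compound 2 (beyond the scatter). Compound 3 is therefore expected to stay near compound 2, with a step of a number 0.07 log units higher from compound 2 to compound 3 (within the scatter) inside the scatter, estimated at 6.05 within 5.55 to 6.55.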

Compound 3, negative logarithm of the antagonist equilibrium constant: 5
Compound 3: the middle estimate sits 1.05 log units above what was measured; measured number outside the range, below it.
By their numbers in this assay, from the lowest: compound 3; then compound 1; then compound 2.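

In this assay the outcome at this position depends on which group sits there: chloro in place of methyl gives a number 0.98 log units lower from compound 2 to compound 3 (beyond the scatter) and chloro in place of hydrogen gives a number 0.34 log units lower from compound 1 to compound 3 (beyond the scatter). Substitution on this aromatic carbon therefore does not raise the number by itself, since methyl and chloro move it in opposite directions from compound 1. Nothing available here accounts for this difference. Where an amine or a trifluoromethyl group at this carbon would fall remains open, as does whether chloro behaves the same way on other aromatic carbons of the shared core.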